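Does a 2-methoxyphenyl group keep the half-life at its limit?

The source may hold more compounds than are shown below. What is called first, only, known or untested is meant among the compounds shown, and "the series" means these compounds.

- Compound 1 `COc1cccc(CNC(=O)N2C(=O)c3ccccc3S2(=O)=O)c1` gives > 166 h (a limit)
- Compound 2 `O=C(NCc1ccccc1Cl)N1C(=O)c2ccccc2S1(=O)=O` gives > 166 h (a limit)
- Compound 3 `O=C(NCC1CCCCC1)N1C(=O)c2ccccc2S1(=O)=O` gives > 166 h (a limit)

In a physicochemical assay for pharmacokinetics (a lower number here means that the compound disappears faster, a higher number that the compound lasts longer), compound 3 gives > 166 h as a limit and not a number. Its exact place among the other compounds therefore cannot be read.

Compound 4 `COc1ccccc1CNC(=O)N1C(=O)c2ccccc2S1(=O)=O` keeps the shared core and carries 2-methoxyphenyl in place of cyclohexyl on a saturated chain carbon bound to an amide-type nitrogen.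

Three measured steps exchange groups at this same place. They are a step that the two limits leave unreadable from compound 1 to compound 3 and a step that the two limits leave unreadable from compound 2 to compound 3 and a step that the two limits leave unreadable from compound 1 to compound 2 so none offers a size to build on. Among the compounds with values here, the closest guide is the first of these, which links cyclohexyl with 3-methoxyphenyl.

Compound 4 is expected to sit at the same limit because of the limit of > 166 h in this assay, at which 3 of the 3 values shown sit, and so no step beyond the usual scatter is expected in this assay in either direction. The estimated step is small (a step that the limit leaves unreadable from compound 3 to compound 4). For compound 4 the estimated half-life is 200 h within an expected range of 120 h to 400 h and the assay will most likely report only a limit.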

Compound 4, half-life: > 166 h
Compound 4 ended at the assay's limit; the forecaster's own chance of this, stated with the estimate: 85%; the middle value does not contradict the limit.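

In this assay compound 4 gives > 166 h, which is a limit and not a number. Within the data shown here, no step from compound 1, compound 2 or compound 3 to compound 4 can be read, because all four compounds share the same limit: the limit of > 166 h in this assay, at which 4 of the 4 values shown sit. The compounds shown leave open the actual half-life of each compound and whether any group at this place would shorten it.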